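Methoxy on the pendant phenyl across two dibromo/monobromo cores

This account rests on a few compounds, and the source may have more. Where it says the series, first, only, none or still open, it means among the compounds named here.

Compound 1 `COc1cc(/C=N/Nc2nc(-c3ccccc3)cs2)c(Br)c(Br)c1OC` gives 26500 nM in a functional assay on Caco-2 cells (Homo sapiens) for inhibition, read by MTT assay, with a stated time of 48 h; on this read-out lower numbers stand for stronger inhibition and higher numbers for weaker inhibition. Compound 2 `COc1ccccc1-c1csc(N/N=C/c2cc(OC)c(OC)c(Br)c2Br)n1` reaches only the limit of this assay, > 100000 nM, which is not a number. Compound 3 `COc1cc(/C=N/Nc2nc(-c3ccccc3)cs2)cc(Br)c1OC` gives 64200 nM in this assay.

The change methoxy in place of hydrogen on an aromatic carbon produces the step of an at least 3.7-fold higher number from compound 1 to compound 2 (0.57 log units; beyond the scatter). The cores of compound 1 and compound 3 differ by hydrogen in place of bromo on an aromatic carbon, which produces a 2.4-fold higher number from compound 1 to compound 3 (0.38 log units; beyond the scatter).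

Compound 4 `COc1ccccc1-c1csc(N/N=C/c2cc(Br)c(OC)c(OC)c2)n1` has not been measured in this assay. Going by the values given here, it differs from compound 3 by methoxy in place of hydrogen on an aromatic carbon, the same change as the one from compound 1 to compound 2, at a place described in the same words.

The expected step is a 3.7-fold higher number from compound 3 to compound 4 (0.57 log units; beyond the scatter), resting on compound 3 at 64200 nM and on the earlier step of an at least 3.7-fold higher number from compound 1 to compound 2 (0.57 log units; beyond the scatter). As compound 3 already sits close to the limit of > 100000 nM in this assay, at which 1 of the 3 values shown sits, compound 4 is expected to reach that limit rather than give a number. The estimate for compound 4 is 240000 nM, between 100000 nM and 600000 nM.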

Compound 4, half-maximal inhibitory concentration: > 100000 nM
Compound 4 was reported as a limit (the forecaster's own chance of this, stated with the estimate: 70%); the middle value does not contradict the limit.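

Replacing phenyl with 2-methoxyphenyl on the core of compound 3 gives an at least 1.5-fold higher number from compound 3 to compound 4 (0.19 log units; that floor lies within the scatter), a result that fits the direction seen on the core of compound 1, although this floor alone does not establish a change on the core of compound 3. The series therefore does not show that a step of fixed size carries from one core to the other, and the two steps cannot be ranked: the same change on two cores in this assay, an at least 3.7-fold higher number (0.57 log units; beyond the scatter) from compound 1 to compound 2 and an at least 1.5-fold higher number (0.19 log units; that floor lies within the scatter) from compound 3 to compound 4; the limit leaves it open whether they differ. Compound 2 and compound 4 are both reported only as limits in this assay, the step between them cannot be read, and the scale offers little room to follow weaker compounds: the limit of > 100000 nM in this assay, at which 2 of the 4 values shown sit.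

Open, as far as these compounds go, is whether a hydroxy group, an amine or a carboxylic acid in place of the methoxy on the 2-methoxyphenyl would bring a number back within the range of the read-out. Also open, from the compounds shown here alone, is the size of the methoxy step on a core whose value lies well clear of the limit.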